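This account rests on a few compounds, and the source may have more. Where it says the series, first, only, none or still open, it means among the compounds named here.

Measured compounds:
compound 1, `COc1ccc(/C=C/C=C/C(=O)c2cc(Cl)ccc2O)cc1`, 153 nM
compound 2, `COc1cc(/C=C/C(O)=C/C(=O)c2c(O)cccc2OC)ccc1O`, 1680 nM
compound 3, `COc1ccc(/C=C/C=C/C(=O)c2ccccc2O)cc1`, 1810 nM

The read-out throughout is an in vitro assay on cells for inhibition of Amine oxidase [flavin-containing] B (Homo sapiens), read by Amplex Red, with a stated time of 15 min; a lower number here means a stronger inhibitor, a higher number a weaker inhibitor. Compound 1 gives the lowest number of the three; compound 2 comes next at 1680 nM, and compound 3 stands furthest at 1810 nM, both separations beyond the scatter. Going by the values given here, the only single-point step available, a 12-fold higher number from compound 1 to compound 3 (1.07 log units; beyond the scatter), shows that the chloro on the aromatic carbon carries the whole difference between compound 1 and compound 3.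

Compound 4, `O=C(/C=C/C=C/c1ccccc1)c1cc(Cl)ccc1O`, keeps that chloro and differs from compound 1 in one place: hydrogen in place of methoxy on an aromatic carbon. Among the compounds with values here, no measured pair isolates this change; compound 2 and compound 3 differ from each other in several places at once, so their two values cannot be read as a methoxy effect. Within the data shown here, with no direct precedent, the step from compound 1 to compound 4 is expected to be small to moderate, more likely towards a higher number than a lower one, and is estimated as a 2.1-fold higher number from compound 1 to compound 4 (0.32 log units; beyond the scatter). For compound 4 the expected value in this assay is 320 nM, within a range of 100 nM to 1000 nM.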

Compound 4, half-maximal inhibitory concentration: 54.8 nM
Compound 4: middle estimate off by 5.8-fold (0.77 log units), on the high side, outside the stated range (below it).
By their numbers in this assay, from the lowest: compound 4; then compound 1; then compounds 2 and 3 (each within the scatter of the next).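

In this assay, going by these compounds alone, hydrogen in place of methoxy on the aromatic carbon para to a large group gives a 2.8-fold lower number from compound 1 to compound 4 (0.45 log units; beyond the scatter), the first single-place reading at this position. In this chloro-bearing pair, the methoxy is therefore not required for a low number, and the unsubstituted position gives the lower value, with compound 4 at 54.8 nM. Nothing available explains this step.

Going by these compounds, only hydrogen and methoxy can be compared at this position, so the response to a fluoro, a methyl, an amine or a longer alkoxy chain remains open, as does whether any group there can match or improve on hydrogen. Also open, on these data alone, is whether the step carries over to a partner without the chloro, and whether the gain seen with chloro in a 12-fold higher number from compound 1 to compound 3 (1.07 log units; beyond the scatter) persists in the absence of the methoxy.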